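Urea series on Raji cells: aryl change at the amide nitrogen

A few compounds are considered here, and "the series" means these few. Any claim that something is new, unique, unknown or untested is made for them only; others in the source may bear on it.

Compound 2 `Cc1cc(NC(=O)Nc2ncccc2C)c2ccccc2n1` has only a limit in an ADME assay on Raji cells (Homo sapiens) for cytotoxicity, with a stated time of 72 h; on this read-out higher numbers stand for an effect only at larger amounts of compound and lower numbers for an effect already at smaller amounts: compound 2 gives > 25000 nM, a limit and not a number. Compound 1 `Cc1cc(NC(=O)Nc2ccc(C(=O)O)cc2)c2ccccc2n1` likewise gives a limit, > 25000 nM, in this assay. Both values sit at the limit of > 25000 nM in this assay, at which 2 of the 2 values shown sit, so compound 2 cannot be placed relative to compound 1 on these numbers. Compound 3 `Cc1cc(NC(=O)Nc2ccccc2F)c2ccccc2n1` differs from compound 2 by 2-fluorophenyl in place of 3-methylpyridin-2-yl on an amide-type nitrogen. For the measured compounds named here, no measured step between compounds is available for this change, so no direction can be read from the series. The expected step of a number no higher from compound 2 to compound 3 (the limit leaves the size open) is none beyond the scatter. Compound 3 is expected at 25000 nM, between 8000 nM and 60000 nM, most likely again only a limit.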

Compound 3, half-maximal effective concentration: > 25000 nM
Compound 3 ended at the assay's limit; the forecaster's own chance of this, stated with the estimate: 75%; the middle value lies on the limit itself.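

Compound 2 and compound 3 both end at a limit, so no step can be read between them: the limit of > 25000 nM in this assay, at which 3 of the 3 values shown sit. On these data alone, whether 2-fluorophenyl and 3-methylpyridin-2-yl on the amide-type nitrogen differ in effect stays open.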